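Replacing a benzyl ester by an amino-methoxy anilide

The source may hold more compounds than are shown below. What is called first, only, known or untested is meant among the compounds shown, and "the series" means these compounds.

The shared core of these compounds carries a sulfonyl-linked aryl ether on a spiro-fused saturated ring system, and the series differs only in the group attached to its carbonyl carbon. Compound 1 `O=C(OCc1ccccc1)C1(S(=O)(=O)c2ccc(Oc3ccc(OC(F)(F)F)cc3)cc2)CCC2(CCNCC2)C1` holds a benzyloxy group there. In a functional assay on blood (Homo sapiens), with a stated time of 60 min, in the presence of a further agent that is not named here (on this read-out lower numbers stand for an effect already at smaller amounts and higher numbers for an effect only at larger amounts of compound), compound 1 gives > 15000 nM, which is a limit of the assay rather than a number. For the measured compounds named here, compound 1 thus shares the position described by the limit of > 15000 nM in this assay, at which 2 of the 3 values shown sit, while only one compound reaches (the limit of <= 400 nM in this assay, at which 1 of the 3 values shown sits).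

Compound 4 `COc1ccc(N)c(NC(=O)C2(S(=O)(=O)c3ccc(Oc4ccc(OC(F)(F)F)cc4)cc3)CCC3(CCNCC3)C2)c1` is the unmeasured partner; it differs from compound 1 by (2-amino-5-methoxyphenyl)amino in place of benzyloxy on a carbonyl carbon.

Going by the values given here, two measured steps bear on this. Compound 3 `Nc1ccc(F)cc1NC(=O)C1(S(=O)(=O)c2ccc(Oc3ccc(OC(F)(F)F)cc3)cc2)CCC2(CCNCC2)C1` carries a (2-amino-5-fluorophenyl)amino group; in this assay compound 3 gives > 15000 nM, again a limit. The step that the two limits leave unreadable from compound 1 to compound 3 therefore cannot be read. Compound 2 `Nc1ccc(-c2ccccc2)cc1NC(=O)C1(S(=O)(=O)c2ccc(Oc3ccc(OC(F)(F)F)cc3)cc2)CCC2(CCNCC2)C1`, with a phenyl group in place of the fluoro, gives <= 400 nM, also a limit. The step of an at least 37-fold higher number from compound 2 to compound 3 (1.57 log units; beyond the scatter) shows that a small substituent on the anilide ring leaves the compound at the weak end.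

Because compound 3 sits at the limit of > 15000 nM in this assay, at which 2 of the 3 values shown sit, compound 4 is expected to remain weak, with an estimated step of an at least 1.2-fold lower number from compound 1 to compound 4 (0.09 log units; that floor lies within the scatter). Compound 4 is estimated at 12000 nM, within 2000 nM to 50000 nM.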

Compound 4, half-maximal effective concentration: 3700 nM
Estimate against measurement, compound 4: 3.2-fold (0.51 log units) above; low and high end bracket the measured number.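

In this assay, for the compounds shown here, compound 4 gives 3700 nM, the only value shown that is a number and not a limit, so this place on the anilide ring now has a reading between the two ends of the series. Methoxy in place of fluoro is enough to leave the weak end, with an at least 4.0-fold lower number from compound 3 to compound 4 (0.60 log units; beyond the scatter), and the whole exchange of the benzyloxy group for (2-amino-5-methoxyphenyl)amino gives an at least 4.0-fold lower number from compound 1 to compound 4 (0.60 log units; beyond the scatter). Phenyl still reaches further, as methoxy in its stead gives an at least 9.2-fold higher number from compound 2 to compound 4 (0.96 log units; beyond the scatter), so the three groups rank phenyl, methoxy, fluoro, and as all three steps rest on a limit, each gives only a minimum size.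

As far as these compounds go, the step between compound 1 and compound 3 cannot be read, as both values are limits, so it stays unknown how the fluoro anilide compares with the benzyl ester. The compounds shown also leave open how a chloro, methyl, ethoxy or dimethylamino group would read at this place, and so whether the ranking of these three groups extends to others.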